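The source may report more compounds than this note shows. Statements on the series, on what has been measured and on what is new or still open speak of the compounds shown alone.

Working notes on the series around the shared core, read in a functional assay on B16 cells (Mus musculus) for inhibition, with a stated time of 72 h (on this read-out lower numbers stand for stronger inhibition and higher numbers for weaker inhibition), throughout. Compound 1 `O=C1NCCCN1Cc1ccccc1` gives > 10000 nM as a limit of the assay and not as a number. Compound 2 `COc1ccc(CN2CCCNC2=O)cc1` gives > 10000 nM and this too is a limit. Compound 3 `CCc1ccc(CN2CCCNC2=O)cc1` gives > 10000 nM as a limit as well, so it has no number of its own and stands level with the other two only in that sense.

Compound 4 `CC(C)c1ccc(CN2CCCNC2=O)cc1` differs from compound 3 by methyl in place of hydrogen on a saturated chain carbon bound to an aromatic carbon and a saturated chain carbon with methyl in place of hydrogen on a saturated chain carbon bound to an aromatic carbon and a saturated chain carbon, ethyl to isopropyl.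

Within the data shown here, the steps that bear on this are a step that the two limits leave unreadable from compound 1 to compound 3 for ethyl in place of hydrogen, a step that the two limits leave unreadable from compound 1 to compound 2 for methoxy in place of hydrogen and a step that the two limits leave unreadable from compound 2 to compound 3 for ethyl in place of methoxy. None has a readable size, and the whole record is the limit of > 10000 nM in this assay, at which 3 of the 3 values shown sit, for now. No step beyond the scatter is therefore expected in this assay and no direction can be given. The estimated step is a step that the limit leaves unreadable from compound 3 to compound 4 and it is expected to stay small. Compound 4 is expected at 20000 nM with an estimated range from 8000 nM to 60000 nM and will most likely be reported only as a limit.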

Compound 4, half-maximal inhibitory concentration: > 10000 nM
Compound 4: only a limit was reported; the forecaster's own chance of this, stated with the estimate: 85%; the middle value is on the limit's open side.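

In this assay compound 4 gives > 10000 nM, which is a limit of the assay and not a number. The steps to compound 4 from compound 1, compound 2 and compound 3 therefore cannot be read. The compounds shown leave open whether any change on the shared core gives a readable value in this assay, and the whole record so far is: the limit of > 10000 nM in this assay, at which 4 of the 4 values shown sit.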